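The compounds below may be only part of what the source reports. "The series", "measured", "known", "first", "only" and "open" are said of these compounds alone.

Measured compounds:
compound 1, `CC(O)(COc1ccc(C#N)cc1)C(=O)Nc1cccc(S(F)(F)(F)(F)F)c1` — 32500 nM
compound 2, `CC(O)(COc1ccc(C#N)cc1C(F)(F)F)C(=O)Nc1cccc(S(F)(F)(F)(F)F)c1` — 18300 nM
compound 3, `CC(O)(CS(=O)(=O)c1cccc(C(F)(F)F)c1)C(=O)Nc1cccc(S(F)(F)(F)(F)F)c1` — 24600 nM

All three were tested in a functional assay on CWR22R cells (Homo sapiens) for antiproliferative activity, read by propidium iodide staining, with a stated time of 96 h; a lower number here means a stronger inhibitor, a higher number a weaker inhibitor. Compound 2 differs from compound 1 by trifluoromethyl in place of hydrogen on an aromatic carbon, and that step gave a 1.8-fold lower number from compound 1 to compound 2 (0.25 log units; within the scatter). Compound 3 has a core that is not that of compound 1; the difference between the two cores is not broken down here. Compound 3 and compound 1 give numbers that lie within the scatter of one another, as do compound 3 and compound 2.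

Compound 4, `CC(O)(CS(=O)(=O)c1cc(C(F)(F)F)cc(C(F)(F)F)c1)C(=O)Nc1cccc(S(F)(F)(F)(F)F)c1`, has not yet been measured. It differs from compound 3 by trifluoromethyl in place of hydrogen on an aromatic carbon. This is the same kind of change as that from compound 1 to compound 2, but the surroundings differ: in compound 2 the new group sits ortho to a large group and meta to a cyano group, whereas in compound 4 it sits meta to a large group and meta to a trifluoromethyl group. The earlier step stayed within the scatter, so a similarly small step is expected from compound 3 to compound 4, namely a 1.6-fold lower number from compound 3 to compound 4 (0.21 log units; within the scatter). Compound 4 is therefore estimated at 15000 nM, with a likely range from 6000 nM to 40000 nM.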

Compound 4, half-maximal inhibitory concentration: 9300 nM
Estimate against measurement, compound 4: 1.6-fold (0.21 log units) above; low and high end bracket the measured number.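

In this assay, trifluoromethyl in place of hydrogen on an aromatic carbon gave a 2.6-fold lower number from compound 3 to compound 4 (0.42 log units; beyond the scatter), so the number also fell on this second core. Set beside the earlier step, the two cannot be told apart in size: the same change on two cores in this assay, a 1.8-fold lower number (0.25 log units; within the scatter) from compound 1 to compound 2 and a 2.6-fold lower number (0.42 log units; beyond the scatter) from compound 3 to compound 4, 1.5-fold (0.17 log units) apart, within the scatter of two such steps. Among these compounds, the change therefore carried over in the same direction and to a comparable extent, but this rests on only two pairs, and only the step on the second core lies beyond the scatter, so it shows neither a general rule for the series nor why the change acts as it does.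

The compounds shown leave open whether a different group on that aromatic carbon, such as a chlorine atom, a methoxy group or an amine, would give a similar step. They also leave open whether the trifluoromethyl step would hold on a core with a carboxylic acid or a longer chain in place of the parts shared here.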